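Swapping the amide substituent in a bromoquinoline carboxamide series

The source may report more compounds than this note shows. Statements on the series, on what has been measured and on what is new or still open speak of the compounds shown alone.

Compound 1 `N[C@H]1CC[C@H](Nc2c(C(=O)NCc3cccc(C(F)(F)F)c3)nc(Br)c3cccnc23)CC1` gives "not determined" (no result reported) in a functional assay on HCT-116 cells (Homo sapiens) for cytotoxicity, read by MTT assay, with a stated time of 72 h (on this read-out lower numbers stand for stronger inhibition and higher numbers for weaker inhibition), and compound 2 `O=C(NCc1ccc(F)cc1)c1nc(NCCO)c2cccnc2c1O` likewise gives "not determined" (no result reported). The only figure in this assay belongs to compound 3 `N[C@H]1CC[C@H](NC(=O)c2nc(Br)c3cccnc3c2NCc2ccc(F)cc2)CC1`, which gives 6400 nM. Compound 4 `C[C@H](NC(=O)c1nc(Br)c2cccnc2c1N[C@H]1CC[C@H](N)CC1)c1ccc(F)cc1` differs from compound 1 by 1-(4-fluorophenyl)ethyl in place of 3-(trifluoromethyl)benzyl on an amide-type nitrogen. Within the data shown here, no measured pair shows what this change does in this assay, so no direction or size can be read for the step from compound 1 to compound 4; only a guess is possible. Taking the single measured figure of compound 3 as the sole anchor, compound 4 is expected to give about 5000 nM, with a likely range from 1000 nM to 30000 nM.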

Compound 4, half-maximal inhibitory concentration: > 10000 nM
Compound 4 was reported as a limit; the forecaster's own chance of this, stated with the estimate: 25%; at least 2.0-fold (0.30 log units) between middle value and limit.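

In this assay compound 4 gives > 10000 nM, which is a limit and not a number. Among these compounds, compound 1 has no single figure here, so no step from compound 1 to compound 4 can be read. From the compounds shown here alone, what replacing 3-(trifluoromethyl)benzyl with 1-(4-fluorophenyl)ethyl does to the read-out stays open.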